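A few compounds are considered here, and "the series" means these few. Any claim that something is new, unique, unknown or untested is made for them only; others in the source may bear on it.

Compound 1 `COc1ccc(S(=O)(=O)/C(=C/c2ccc(C)s2)C(=O)c2ccc(Cl)cc2)cc1` gives 25000 nM in a functional assay on DU-145 cells (Homo sapiens) for inhibition, read by trypan blue exclusion, with a stated time of 96 h (on this read-out lower numbers stand for stronger inhibition of growth and higher numbers for weaker inhibition of growth), the highest of the two numbers in hand. Compound 2 `Cc1ccc(S/C(=C/c2c[nH]c3ccc(Br)cc23)C(=O)c2ccc(Br)cc2)cc1` gives 1000 nM in this assay, a lower number by a gap beyond the usual scatter; the two structures differ in several places, so the gap is noted without further reading. Compound 3 `Cc1ccc(/C=C(\C(=O)c2ccc(Cl)cc2)S(=O)(=O)Cc2ccc(Cl)cc2)s1` differs from compound 1 by 4-chlorobenzyl in place of 4-methoxyphenyl on a sulfonyl sulfur. Among the measured compounds shown here, no measured pair shows this change, so no step beyond the scatter is expected from compound 1 to compound 3 in this assay; the step expected is a 1.3-fold lower number from compound 1 to compound 3 (0.10 log units; within the scatter). Compound 3 is estimated at 20000 nM, within 5000 nM to 60000 nM.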

Compound 3, concentration for 50% growth inhibition: 1000 nM
Compound 3: middle estimate off by 20-fold (1.30 log units), on the high side; measured number below the stated range.
By their numbers in this assay, from the lowest: compounds 2 and 3 (each within the scatter of the next); then compound 1.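

In this assay, 4-chlorobenzyl in place of 4-methoxyphenyl on a sulfonyl sulfur gives a 25-fold lower number from compound 1 to compound 3 (1.40 log units; beyond the scatter). Among the compounds shown here, this is the first single-place comparison, and it shows that the number is highly sensitive to the group at this position, which the earlier pair, differing in several places, could not show. Nothing on hand accounts for the size of this step.

Still open, going by these compounds, is whether the chlorine or the benzyl carbon carries the step. A 4-chlorophenyl or an unsubstituted benzyl group on the sulfonyl sulfur would separate the two.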